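Allyl for Cyclobutyl on the Shared Core, Without Fluorine

A few compounds are considered here, and "the series" means these few. Any claim that something is new, unique, unknown or untested is made for them only; others in the source may bear on it.

Compound 1, `COc1cc(Cc2nc3c(N)nc(F)nc3n2CC2CCC2)cc(OC)c1OC`, gives 40700 nM in a functional assay on MCF7 cells (Homo sapiens) for antiproliferative activity; a higher number here means a weaker inhibitor, a lower number a stronger inhibitor.
Compound 2, `C=CCCn1c(Cc2cc(OC)c(OC)c(OC)c2)nc2c(N)nc(F)nc21`, gives 33100 nM in this assay.
Compound 3, `COc1cc(Cc2nc3c(N)ncnc3n2CC2CCC2)cc(OC)c1OC`, gives 45700 nM in this assay.

All three measured numbers sit within the usual scatter of one another, so none can be set apart. Compound 4, `C=CCCn1c(Cc2cc(OC)c(OC)c(OC)c2)nc2c(N)ncnc21`, has not yet been measured. It differs from compound 3 by allyl in place of cyclobutyl on a saturated chain carbon bound to an aromatic nitrogen. The same change, (allyl in place of cyclobutyl on a saturated chain carbon bound to an aromatic nitrogen), has already been measured once: it gave a 1.2-fold lower number from compound 1 to compound 2 (0.09 log units; within the scatter). The core of compound 3 differs from that of compound 1 by hydrogen in place of fluoro on an aromatic carbon, a change that on its own gave a 1.1-fold higher number from compound 1 to compound 3 (0.05 log units; within the scatter). Since the place of the allyl-for-cyclobutyl swap is described in identical words in both pairs, the change from compound 3 to compound 4 is the same change, made on a core without the fluoro group.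

Because a 1.2-fold lower number from compound 1 to compound 2 (0.09 log units; within the scatter) stayed within the scatter, the expected step from compound 3 to compound 4 in this assay is a 1.2-fold lower number from compound 3 to compound 4 (0.08 log units; within the scatter), again within the scatter. Compound 4 is therefore estimated at 38000 nM, with a likely range from 20000 nM to 70000 nM.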

Compound 4, half-maximal inhibitory concentration: 40700 nM
Beside the measured number, compound 4's estimate is 1.1-fold (0.03 log units) below it, within the range that was stated.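

In this assay, allyl in place of cyclobutyl gives a 1.1-fold lower number from compound 3 to compound 4 (0.05 log units; within the scatter) on the core without fluoro, and this agrees with the step on the fluorinated core: the same change on two cores in this assay, a 1.2-fold lower number (0.09 log units; within the scatter) from compound 1 to compound 2 and a 1.1-fold lower number (0.05 log units; within the scatter) from compound 3 to compound 4, 1.1-fold (0.04 log units) apart, within the scatter of two such steps
Hydrogen in place of fluoro also behaves alike with either group on the chain, here giving a 1.2-fold higher number from compound 2 to compound 4 (0.09 log units; within the scatter), which agrees with the earlier step: the same change on two cores in this assay, a 1.1-fold higher number (0.05 log units; within the scatter) from compound 1 to compound 3 and a 1.2-fold higher number (0.09 log units; within the scatter) from compound 2 to compound 4, 1.1-fold (0.04 log units) apart, within the scatter of two such steps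
This shows that both changes carry from one core to the other only in the sense that neither produces a readable shift on either core; with every step inside the scatter, it does not show a real effect of either change, nor that the two changes act independently of each other.

From the compounds shown here alone, it remains open whether a different group on the saturated chain carbon bound to an aromatic nitrogen, such as a longer chain or an amine, would move the number beyond the scatter. Going by these compounds, it also remains open whether chloro or methoxy in place of fluoro would do so, and whether any such step would then carry between cores.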